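A Benzyloxy Analogue in a Cytotoxicity Series

The compounds below may be only part of what the source reports. "The series", "measured", "known", "first", "only" and "open" are said of these compounds alone.

Measured compounds:
compound 1, `BrCCCOc1c(Br)cc(Br)cc1Oc1ccc(Br)cc1Br`: 30.3 ug/mL
compound 2, `BrCCCCOc1c(Br)cc(Br)cc1Oc1ccc(Br)cc1Br`: 29 ug/mL
compound 3, `CCOC(=O)C(C)Oc1c(Br)cc(Br)cc1Oc1ccc(Br)cc1Br`: 39.5 ug/mL

All three were tested in a functional assay on U-937 cells (Homo sapiens) for cytotoxicity, read by MTT assay, with a stated time of 24 h; a lower number here means a stronger inhibitor, a higher number a weaker inhibitor. Compound 1 gives 30.3 ug/mL, the second highest of the three numbers. Its nearest neighbour is compound 2, with a 1.0-fold lower number from compound 1 to compound 2 (0.02 log units; within the scatter); its furthest is compound 3, with a 1.3-fold higher number from compound 1 to compound 3 (0.12 log units; within the scatter). Between compound 2 and compound 3 the difference is a 1.4-fold higher number from compound 2 to compound 3 (0.13 log units; within the scatter). Every step among the measured compounds therefore lies within the scatter of repeated measurement.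

Compound 4, `Brc1ccc(Oc2cc(Br)cc(Br)c2OCc2ccccc2)c(Br)c1`, has not yet been measured. It differs from compound 1 in one place: phenyl in place of 2-bromoethyl on a saturated chain carbon bound to an oxygen on an aromatic ring. Going by the values given here, no measured step swaps a chain for a ring, so nothing bears on this change directly. The closest comparisons are the two steps that replaced the group on the oxygen of the aromatic ring to give compound 3, and both stayed within the scatter. On that basis no step beyond the scatter is expected in this assay.

Compound 4 is therefore expected to give about 30 ug/mL, with a range from 15 ug/mL to 60 ug/mL. The expected step, a 1.0-fold lower number from compound 1 to compound 4 (0.00 log units; within the scatter), stays within the scatter.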

Compound 4, half-maximal inhibitory concentration: 29 ug/mL
Compound 4: the middle estimate sits 1.0-fold (0.01 log units) above what was measured; the range from low to high includes it.
By their numbers in this assay, from the lowest: compounds 2, 4, 1 and 3 (each within the scatter of the next).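

In this assay this position now holds an aromatic ring and not only an open chain, and the step from 3-bromopropyl to benzyl stays within the scatter (a 1.0-fold lower number from compound 1 to compound 4 (0.02 log units; within the scatter)). The other two comparisons agree, with a step from the ester-bearing group (a 1.4-fold lower number from compound 3 to compound 4 (0.13 log units; within the scatter)) and one from the 4-bromobutyl chain (no change at the digits printed from compound 2 to compound 4 (within the scatter)), so all four groups on this oxygen remain indistinguishable, even though phenyl brings a six-membered aromatic ring of carbon only and removes the chain's bromine. Nothing measured here explains why the number holds across these groups.

Still open, from the compounds shown here alone, is whether any group on this oxygen can move the number beyond the scatter, for example an amine, a carboxylic acid or a much longer chain. Also open, going by these compounds, is whether a substituted benzyl would behave like the plain benzyl of compound 4.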